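The source may report more compounds than this note shows. Statements on the series, on what has been measured and on what is new or still open speak of the compounds shown alone.

In a functional assay on SH-SY5Y cells (Homo sapiens) for inhibition, read by sulforhodamine B assay (a lower number here means a stronger inhibitor, a higher number a weaker inhibitor), compound 1 `COC(=O)CC/C(C)=C/Cc1c(OC)c(C)c2c(c1OCC#CCN1CCN(c3ccccc3F)CC1)C(=O)OC2` gives 35800 nM and compound 2 `COC(=O)CC/C(C)=C/Cc1c(OC)c(C)c2c(c1OCC#CCN1CCN(Cc3ccc(Cl)cc3)CC1)C(=O)OC2` gives 31200 nM. These two numbers lie within the scatter of each other, so compound 2 stands level with compound 1. Compound 3 `COC(=O)CC/C(C)=C/Cc1c(OC)c(C)c2c(c1OCC#CCN1CCN(C(c3ccccc3)c3ccc(Cl)cc3)CC1)C(=O)OC2` has not yet been measured. Its difference from compound 2 is phenyl in place of hydrogen on a saturated chain carbon bound to an amine nitrogen in a ring and an aromatic carbon. Within the data shown here, one measured step bears on this change: a 1.1-fold lower number from compound 1 to compound 2 (0.06 log units; within the scatter), with 4-chlorobenzyl in place of 2-fluorophenyl on an amine nitrogen in a ring. Among the measured compounds shown here, that step lies within the scatter, and no measured compound carries the added phenyl, so no direction can be drawn and no shift beyond the scatter is expected in this assay. The expected step is a 1.0-fold lower number from compound 2 to compound 3 (0.02 log units; within the scatter). The estimate for compound 3 is 30000 nM, with an expected range of 12000 nM to 60000 nM.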

Compound 3, half-maximal inhibitory concentration: 9900 nM
Compound 3: middle estimate off by 3.0-fold (0.48 log units), on the high side, outside the stated range (below it).
By their numbers in this assay, from the lowest: compound 3; then compounds 2 and 1 (each within the scatter of the next).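

In this assay phenyl in place of hydrogen on a saturated chain carbon bound to an amine nitrogen in a ring and an aromatic carbon gives a 3.2-fold lower number from compound 2 to compound 3 (0.50 log units; beyond the scatter) and so moves the number beyond the scatter. The earlier change on the amine nitrogen, with a 1.1-fold lower number from compound 1 to compound 2 (0.06 log units; within the scatter) as its step, stayed within the scatter, so among the compounds shown, this carbon is the only place where a change moves the number that far. Nothing measured here accounts for the step.

The compounds shown leave open whether the gain needs an aromatic ring on this carbon, or whether a methyl or a cyclohexyl there would give the same step. They also leave open how the step would change with hydrogen or a methoxy group in place of the chlorine.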